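Swapping the benzyl substituent: from difluoro to nitro

The source may hold more compounds than are shown below. What is called first, only, known or untested is meant among the compounds shown, and "the series" means these compounds.

Measured compounds:
- compound 1 `Cc1cc(Nc2nn(-c3ccc(F)cc3)c(=O)c3ccccc23)n[nH]1`: 800 nM
- compound 2 `Cc1cc(Nc2nn(Cc3cc(F)ccc3F)c(=O)c3ccccc23)n[nH]1`: 570 nM
- compound 3 `Cc1ccc(-n2nc(Nc3cc[nH]n3)c3ccccc3c2=O)cc1`: "not determined" (no result reported)

In a functional assay on HCT-116 cells (Homo sapiens) for cytotoxicity, read by CellTiter-Glo, with a stated time of 5 days (on this read-out higher numbers stand for weaker inhibition and lower numbers for stronger inhibition), compound 2 gives 570 nM and compound 1 gives 800 nM; the two sit within the scatter of each other, as the step of a 1.4-fold lower number from compound 1 to compound 2 (0.15 log units; within the scatter) shows. Compound 4 `Cc1cc(Nc2nn(Cc3ccc([N+](=O)[O-])cc3)c(=O)c3ccccc23)n[nH]1` has not been measured. It differs from compound 2 in one place: 4-nitrophenyl in place of 2,5-difluorophenyl on a saturated chain carbon bound to an aromatic nitrogen. Within the data shown here, the only step that bears on this is the change of the group on the aromatic nitrogen, a 1.4-fold lower number from compound 1 to compound 2 (0.15 log units; within the scatter), which stayed within the scatter. A step of similar size is therefore expected, that is, no change beyond the scatter in this assay, giving a 1.1-fold higher number from compound 2 to compound 4 (0.02 log units; within the scatter). Compound 4 is estimated at 600 nM, with a range from 250 nM to 1500 nM.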

Compound 4, half-maximal inhibitory concentration: 1400 nM
For compound 4 the middle estimate is 2.3-fold (0.37 log units) below the measured one; the range from low to high includes it.
By their numbers in this assay, from the lowest: compounds 2, 1 and 4 (each within the scatter of the next, the first and the last beyond it).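

Among these compounds, on a saturated chain carbon bound to an aromatic nitrogen, the aryl group does matter: in this assay 4-nitrophenyl in place of 2,5-difluorophenyl gives a 2.5-fold higher number from compound 2 to compound 4 (0.39 log units; beyond the scatter) and so makes the first modest step here beyond the scatter. The position therefore responds to a change of the ring's substituents, which the earlier step did not reveal. Nothing available explains this step.

Still open, from the compounds shown here alone, is whether the fluorines leaving or the nitro group entering accounts for it. A plain benzyl or a 4-aminobenzyl group at this place could help to separate the two.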